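Swapping the sulfonyl aryl group: chloro for methyl

This account rests on a few compounds, and the source may have more. Where it says the series, first, only, none or still open, it means among the compounds named here.

Compound 3 `CCN(CC)C(=O)CN(c1ccc(C)cc1)S(=O)(=O)c1cccc(Cl)c1` is one of three sulfonamides tested in a functional assay on CHO cells for inhibition of Orexin receptor type 2 (Homo sapiens), read by FLIPR and calcium flux (a higher number here means a weaker inhibitor, a lower number a stronger inhibitor), where it gives 139 nM. Compound 1 `CCN(CC)C(=O)CN(c1cccc(N(C)C)c1C#N)S(=O)(=O)c1ccc(OC)c(OC)c1` gives 110 nM in this assay, a number that sits within the scatter of that of compound 3. Compound 2 `CCN(CC)C(=O)CN(c1ccc(C)cc1)S(=O)(=O)c1ccc(OC(F)(F)F)cc1` gives 1820 nM in this assay, a higher number than compound 3 by a margin beyond the scatter. Compound 3 thus stands with compound 1 at the lower end of the three numbers, with compound 2 apart from both.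

Compound 4 `CCN(CC)C(=O)CN(c1ccc(C)cc1)S(=O)(=O)c1ccccc1C` differs from compound 3 in one place: 2-methylphenyl in place of 3-chlorophenyl on a sulfonyl sulfur. For the measured compounds named here, no measured pair in this set shows the same change, so nothing here tells how the move from 3-chlorophenyl to 2-methylphenyl plays out. The author expects a modest rise in the number, a 2.2-fold higher number from compound 3 to compound 4 (0.33 log units; beyond the scatter), though a result inside the scatter would not surprise. In this assay compound 4 is therefore estimated at 300 nM, with a likely range from 100 nM to 900 nM.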

Compound 4, half-maximal inhibitory concentration: 58 nM
Estimate against measurement, compound 4: 5.2-fold (0.71 log units) above; measured number outside the range, below it.
By their numbers in this assay, from the lowest: compounds 4, 1 and 3 (each within the scatter of the next, the first and the last beyond it); then compound 2.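

On a sulfonyl sulfur whose other neighbour is the sulfonamide nitrogen, 2-methylphenyl in place of 3-chlorophenyl gives a 2.4-fold lower number from compound 3 to compound 4 (0.38 log units; beyond the scatter) in this assay. For the compounds shown here, this is the first step in the set that reads a single change, and it shows that this position can take an aryl group without chlorine and still give a lower number. Nothing measured here explains the step.

The compounds shown leave open whether the step comes from the methyl group itself or from its place on the ring, and a plain phenyl or a methoxyphenyl group on the same sulfur would help to separate the two. They also leave open whether the same change would give a similar step on the core of compound 1.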